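Pyrrole for iodophenyl in a cytotoxicity series

This account rests on a few compounds, and the source may have more. Where it says the series, first, only, none or still open, it means among the compounds named here.

Compound 2 `O=C(/C=C/c1ccc2c(c1)B(O)OC2)c1ccc(I)cc1` is one of three enones on a shared core. In an ADME assay on L929 cells (Mus musculus) for cytotoxicity, read by resazurin assay, with a stated time of 72 h (a higher number here means a weaker inhibitor, a lower number a stronger inhibitor), compound 2 gives only a limit, > 10 ug/mL, and no number. Compound 1 `O=C(/C=C/c1ccc2c(c1)B(O)OC2)c1ccc(C(F)(F)F)cc1` likewise sits at a limit of > 10 ug/mL in this assay. Compound 3 `CSc1ccc(C(=O)/C=C/c2ccc3c(c2)B(O)OC3)cc1` also stops at a limit of > 10 ug/mL in this assay. Hence (the limit of > 10 ug/mL in this assay, at which 3 of the 3 values shown sit), and the steps a step that the two limits leave unreadable from compound 1 to compound 2, a step that the two limits leave unreadable from compound 1 to compound 3 and a step that the two limits leave unreadable from compound 2 to compound 3 cannot be sized. Compound 4 `Cn1cccc1C(=O)/C=C/c1ccc2c(c1)B(O)OC2` is not yet measured; it differs from compound 2 by 1-methyl-1H-pyrrol-2-yl in place of 4-iodophenyl on a carbonyl carbon. The three measured steps each change one group on an aromatic carbon, and given the limit of > 10 ug/mL in this assay, at which 3 of the 3 values shown sit, none of them moved a value off the limit, so no readable shift is expected in this assay for the present change either, in neither direction. Compound 4 is therefore expected to remain around the limit. In this assay compound 4 is estimated at 20 ug/mL, between 7 ug/mL and 60 ug/mL. This amounts to an expected step that the limit leaves unreadable from compound 2 to compound 4.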

Compound 4, half-maximal inhibitory concentration: > 10 ug/mL
Compound 4: a limit, no number (the forecaster's own chance of this, stated with the estimate: 75%); the middle value does not contradict the limit.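

Compound 2 and compound 4 both give only a limit, so the step between them cannot be read: the limit of > 10 ug/mL in this assay, at which 4 of the 4 values shown sit. The compounds shown leave open whether any of these groups shifts the read-out in this assay at all; none of them yields a number.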